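The source may report more compounds than this note shows. Statements on the series, on what has been measured and on what is new or still open speak of the compounds shown alone.

Measured so far in a functional assay on MDA-MB-231 cells (Homo sapiens) for antiproliferative activity, read by sulforhodamine B assay, with a stated time of 48 h; a lower number here means a stronger inhibitor of growth, a higher number a weaker inhibitor of growth:
- compound 1 `O=C1COc2ccccc2N1CCCn1cc(-c2ccccc2)nn1`: 4900 nM
- compound 2 `O=C1COc2ccccc2N1CCCn1cc(-c2ccccn2)nn1`: 4800 nM
- compound 3 `O=C1COc2ccccc2N1CCCn1cc(-c2cccnc2)nn1`: 3000 nM

Compound 3, at 3000 nM, sits within the scatter of both others: a 1.6-fold lower number from compound 1 to compound 3 (0.21 log units; within the scatter) and a 1.6-fold lower number from compound 2 to compound 3 (0.20 log units; within the scatter).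

Compound 4 `CCCc1cn(CCCN2C(=O)COc3ccccc32)nn1` carries propyl in place of pyridin-3-yl on an aromatic carbon.

The nearest evidence is the aromatic swaps, including a 1.0-fold lower number from compound 1 to compound 2 (0.01 log units; within the scatter), and all stay within the scatter. None of them puts a group without a ring at this place, so the range is kept wide. In this assay, no step beyond the scatter is expected.

The expected step is a 1.7-fold higher number from compound 3 to compound 4 (0.22 log units; within the scatter). For compound 4 the estimate is 5000 nM, with an expected range of 1800 nM to 14000 nM.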

Compound 4, concentration for 50% growth inhibition: 1100 nM
For compound 4 the middle estimate is 4.5-fold (0.66 log units) above the measured one; measured number below the stated range.
By their numbers in this assay, from the lowest: compound 4; then compounds 3, 2 and 1 (each within the scatter of the next).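

In this assay, among these compounds, propyl is the first group without a ring at this aromatic carbon, and it gives the first steps beyond the scatter: a 2.7-fold lower number from compound 3 to compound 4 (0.44 log units; beyond the scatter) and a 4.4-fold lower number from compound 2 to compound 4 (0.64 log units; beyond the scatter) and a 4.5-fold lower number from compound 1 to compound 4 (0.65 log units; beyond the scatter) in the same direction. A ring at this position is therefore not needed for growth inhibition, and the three aromatic groups are all weaker here than propyl. No measurement bears on why the number falls with this change.

The compounds shown leave open whether methyl, a longer chain such as hexyl, or a saturated ring such as cyclohexyl would match propyl. They also leave open how a propyl chain carrying an amine or a carboxylic acid would behave.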